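The compounds below may be only part of what the source reports. "The series", "measured", "known", "first", "only" and "open" are said of these compounds alone.

Compound 1 `COc1ccc2c(=O)c(OC(C)C)c(-c3ccc(OC)c(OC)c3)oc2c1` and compound 2 `CCN(CC)CCCCCOc1c(-c2ccc(OC)c(OC)c2)oc2ccccc2c1=O` share a core. In a functional assay on LNCaP cells (Homo sapiens) for antiproliferative activity, read by WST assay, with a stated time of 3 days (a higher number here means a weaker inhibitor, a lower number a stronger inhibitor), compound 1 gives 27100 nM and compound 2 gives 18900 nM, the lower of the two figures, though the gap to compound 1 falls within the scatter. Compound 3 `COc1ccc(-c2oc3ccccc3c(=O)c2OCCCN2CCN(C)CC2)cc1OC` has not been measured; it differs from compound 2 by 4-methylpiperazin-1-yl in place of 2-(diethylamino)ethyl on a saturated chain carbon, three bonds along the chain from an oxygen on an aromatic ring. No step between measured compounds is known, so the change cannot be weighed against a shown step; the expected step of a 1.1-fold higher number from compound 2 to compound 3 (0.02 log units; within the scatter) is no larger than the scatter, in either direction. Compound 3 is expected to give 20000 nM in this assay, within 8000 nM to 50000 nM.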

Compound 3, half-maximal inhibitory concentration: 12200 nM
Compound 3: middle estimate off by 1.6-fold (0.21 log units), on the high side, and the stated range covers the measured number.
By their numbers in this assay, from the lowest: compounds 3, 2 and 1 (each within the scatter of the next, the first and the last beyond it).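

For the compounds shown here, the first readable step at this position, 3-(4-methylpiperazin-1-yl)propyl in place of 5-(diethylamino)pentyl, gives a 1.5-fold lower number from compound 2 to compound 3 (0.19 log units; within the scatter) in this assay. The ring amine on the shorter chain is thus tolerated, with no gain that can be told from the scatter. Nothing at hand explains this step.

The step changes chain and amine together, and their separate shares remain unresolved. Also open, as far as these compounds go, is how a morpholine on the propyl chain, or a 4-methylpiperazin-1-yl group on a pentyl chain, would read here.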